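Swapping an arylamine for a cyclic amine on the quinone core

A few compounds are considered here, and "the series" means these few. Any claim that something is new, unique, unknown or untested is made for them only; others in the source may bear on it.

Among the compounds with values here, compound 1 `Cc1ccc(NC2=CC(=O)c3nc4n(c3C2=O)[C@H]2OC[C@@H](O)[C@H]2OC4)cc1` is the only compound of this set to give a number in a functional assay on HeLa cells (Homo sapiens) for inhibition, read by sulforhodamine B assay; a lower number here means a stronger inhibitor, a higher number a weaker inhibitor: compound 1 gives 3860 nM. Compound 2 `O=C1C(N2CCCCC2)=CC(=O)c2c1nc1n2[C@H]2OC[C@@H](O)[C@H]2OC1` carries a piperidin-1-yl group on the same double-bonded ring carbon, and in this assay compound 2 reaches only the limit > 16000 nM. Compound 3 `O=C1C(N2CCC2)=CC(=O)c2c1nc1n2[C@H]2OC[C@@H](O)[C@H]2OC1` carries an azetidin-1-yl group there, and in this assay compound 3 likewise returns the limit > 16000 nM. The step that the two limits leave unreadable from compound 2 to compound 3 therefore cannot be sized. Compound 4 `O=C1C=C(N2CCCC2)C(=O)c2c1nc1n2[C@H]2OC[C@@H](O)[C@H]2OC1` is not yet measured; it differs from compound 1 by pyrrolidin-1-yl in place of (4-methylphenyl)amino on a double-bonded ring carbon. Within the data shown here, no measured step runs from an arylamine to a cyclic amine, so nothing fixes the size of this change; but the two cyclic amines already tested, compounds 2 and 3, both sit at the limit of > 16000 nM in this assay, at which 2 of the 3 values shown sit, so a loss is the expectation rather than a gain. Compound 4 is expected to fall well short of compound 1, with an estimated step of a 5.2-fold higher number from compound 1 to compound 4 (0.71 log units; beyond the scatter). For compound 4 the estimate in this assay is 20000 nM, within 6000 nM to 60000 nM, and a limit rather than a number is the likelier outcome.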

Compound 4, half-maximal inhibitory concentration: > 16000 nM
Compound 4 gave a limit, no number; the forecaster's own chance of this, stated with the estimate: 65%; the middle value is on the limit's open side.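

Putting pyrrolidin-1-yl in place of (4-methylphenyl)amino on a double-bonded ring carbon gives an at least 4.1-fold higher number from compound 1 to compound 4 (0.61 log units; beyond the scatter), the first readable step from the arylamine to a cyclic amine in this assay. This step sets only a minimum for the loss, as compound 4 returns a limit, > 16000 nM. With compound 2, compound 3 and compound 4 all at a limit, none of the cyclic amines shown gives a number, and the arylamine of compound 1 alone does: the limit of > 16000 nM in this assay, at which 3 of the 4 values shown sit.

The steps among these limits cannot be read, so the compounds shown do not rank the three cyclic amines. From the compounds shown here alone, it also stays open whether a cyclohexylamino group, which keeps the amine hydrogen but has no aromatic ring, would give a number in this assay.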